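The source may report more compounds than this note shows. Statements on the series, on what has been measured and on what is new or still open speak of the compounds shown alone.

In an in vitro ADME assay on microsomes from liver (Macaca fascicularis) for metabolic stability (a lower number here means slower removal, a higher number faster removal of the compound), compound 1 (`CCC(CC)[C@@H]1C(=O)N[C@H](C2Cc3ccccc3C2)C(=O)N1[C@@H](C(=O)N1CCOCC1)c1ccc(C)nc1`) gives 18 mL.min-1.g-1, within the scatter of compound 2 (`CCC(CC)[C@@H]1C(=O)N[C@H](C2Cc3ccccc3C2)C(=O)N1[C@@H](C(=O)N1CCOCC1)c1ccc(C)nc1C`) at 14 mL.min-1.g-1 and of compound 3 (`CCC(CC)[C@@H]1C(=O)N[C@H](C2Cc3ccccc3C2)C(=O)N1[C@@H](C(=O)N(C)C)c1ccc(C)nc1`) at 12 mL.min-1.g-1. Compound 4 (`CC[C@H](C)[C@@H]1C(=O)N[C@H](C2Cc3ccccc3C2)C(=O)N1[C@@H](C(=O)N1CCOCC1)c1ccc(C)nc1`) differs from compound 1 in one place: sec-butyl in place of pentan-3-yl on a saturated ring carbon. Neither measured step alters that group: methyl in place of hydrogen on an aromatic carbon gave a 1.3-fold lower number from compound 1 to compound 2 (0.11 log units; within the scatter), and dimethylamino in place of morpholin-4-yl on a carbonyl carbon gave a 1.5-fold lower number from compound 1 to compound 3 (0.18 log units; within the scatter). No measurement covers this place, so no step beyond the scatter is expected in this assay, and no direction can be assigned with confidence. The estimated step is a 1.1-fold lower number from compound 1 to compound 4 (0.05 log units; within the scatter). For compound 4 the expected value is 16 mL.min-1.g-1, with an estimated range from 9 mL.min-1.g-1 to 28 mL.min-1.g-1.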

Compound 4, intrinsic clearance in microsomes: 6 mL.min-1.g-1
Compound 4: the middle estimate sits 2.7-fold (0.43 log units) above what was measured; measured number below the stated range.
By their numbers in this assay, from the lowest: compounds 4, 3, 2 and 1 (each within the scatter of the next, the first and the last beyond it).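

Swapping pentan-3-yl for sec-butyl on the saturated ring carbon gives a 3.0-fold lower number from compound 1 to compound 4 (0.48 log units; beyond the scatter) in this assay, the only step shown that lies beyond the scatter. This place, which neither earlier step touched, therefore registers in this read-out, even with an all-carbon group replaced by another all-carbon group. No evidence bearing on the reason for this step is available.

On these data alone, whether the step follows the shorter chain or the defined stereocentre of sec-butyl stays open, as does how isopropyl or cyclopentyl would read at this carbon. Also open, as far as these compounds go, is whether the step holds alongside the dimethylamino of compound 3.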